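Bromo in Place of Formyl on the Aryl Ring of Compound 2

The source may hold more compounds than are shown below. What is called first, only, known or untested is meant among the compounds shown, and "the series" means these compounds.

In a functional assay on T47D cells (Homo sapiens) for inhibition, read by sulforhodamine B assay, with a stated time of 48 h, tested at 10 uM (on this read-out higher numbers stand for more inhibition at the one concentration tested (going by the name of the read-out) and lower numbers for less inhibition), compound 2 `O=Cc1ccc(-c2cn3ccnc3c(-c3ccc4ncn(C5CCCCC5)c4c3)n2)cc1` gives 98%, the highest of the three measured numbers. Compound 3 `Fc1ccc(-c2cn3ccnc3c(-c3ccc4ncn(C5CCCCC5)c4c3)n2)cc1` gives 33.3% in this assay, and compound 1 `COc1ccc(-c2cn3ccnc3c(-c3ccc4ncn(C5CCCCC5)c4c3)n2)cc1` gives -8.6%. All three measured steps are large and beyond the scatter: a number 106.6 percentage points higher from compound 1 to compound 2 (beyond the scatter), a number 41.9 percentage points higher from compound 1 to compound 3 (beyond the scatter), and a number 64.7 percentage points lower from compound 2 to compound 3 (beyond the scatter).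

Compound 4 `Brc1ccc(-c2cn3ccnc3c(-c3ccc4ncn(C5CCCCC5)c4c3)n2)cc1` differs from compound 2 by bromo in place of formyl on an aromatic carbon. The step that bears most directly on this change is the one in which fluoro replaces formyl, a halogen entering where the formyl group leaves, and that step was a large fall. The step from compound 1 to compound 2 shows from the other side how much of the number of compound 2 rests on the formyl group. A large downward step in this assay is therefore expected for compound 4.

Compound 4 is expected to give 35% in this assay. For compound 4 the expected lower end is 5%. For compound 4 the expected upper end is 70%. This estimate for compound 4 means an expected step of a number 63 percentage points lower from compound 2 to compound 4 (beyond the scatter).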

Compound 4, a percentage reported as inhibition, at one concentration (the size of the read-out at that concentration, not a potency): 55%
Compound 4: the middle estimate sits 20 percentage points below what was measured, within the range that was stated.
By their numbers in this assay, from the lowest: compound 1; then compound 3; then compound 4; then compound 2.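

Bromo in place of formyl gives a number 43 percentage points lower from compound 2 to compound 4 (beyond the scatter) in this assay, so a halogen at this place keeps a sizeable part of the number of compound 2 without matching it. Bromo in place of fluoro gives a number 21.7 percentage points higher from compound 3 to compound 4 (beyond the scatter) and is a modest step, which shows that the two halogens do not read alike here and that the fall seen with fluoro does not fix the level for every halogen. Bromo in place of methoxy gives a number 63.6 percentage points higher from compound 1 to compound 4 (beyond the scatter) and is a large step, so the formyl group is not the only group here that stands well clear of methoxy, although fluoro had already shown this more weakly.

Going by these compounds, whether chloro, a nitrile, an amine or a carboxylic acid on this carbon would stand nearer to formyl or to the halogens remains open. Nothing available on any property of these groups bears on the differences between them.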